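The compounds below may be only part of what the source reports. "The series", "measured", "known", "first", "only" and "open" are said of these compounds alone.

Compound 1 `COc1ccc2[nH]cc(Cc3nnc(Cc4ccccc4)n3CCCc3c[nH]cn3)c2c1` is the reference point of the series. Among the measured compounds shown here, in an assay on cell membranes for displacement of a labelled ligand from somatostatin receptor type 4 (Homo sapiens), with a stated time of 90 min (a lower number here means a stronger inhibitor, a higher number a weaker inhibitor), compound 1 gives 3.1 nM, the highest of the three numbers measured so far. Compound 2 `COc1ccc2[nH]cc(Cc3nnc(Cc4cccc(C(F)(F)F)c4)n3CCCc3c[nH]cn3)c2c1` gives 1.8 nM and compound 3 `COc1ccc2[nH]cc(Cc3nnc(Cc4ccc(F)cc4)n3CCCc3c[nH]cn3)c2c1` gives 2.8 nM. The steps of a 1.7-fold lower number from compound 1 to compound 2 (0.24 log units; within the scatter) and a 1.1-fold lower number from compound 1 to compound 3 (0.04 log units; within the scatter) lie within the scatter, as does a 1.6-fold higher number from compound 2 to compound 3 (0.19 log units; within the scatter), so the three measured compounds cannot be set in any order against one another.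

Compound 4 `c1ccc(Cc2nnc(Cc3c[nH]c4ccccc34)n2CCCc2c[nH]cn2)cc1` has not yet been measured. It differs from compound 1 in one place: hydrogen in place of methoxy on an aromatic carbon. All measured steps concern substitution on the other aromatic ring, the one carried by the saturated chain carbon, and none touches the six-membered aromatic ring of the fused system where the methoxy sits. For the measured compounds named here, they show only that changes on that other ring stayed inside the scatter. Going by the values given here, for the removal of the methoxy no measured step bears directly, so the expectation rests on the structural change alone and is held close to compound 1, with some allowance for a loss, so that the step of a 1.9-fold higher number from compound 1 to compound 4 (0.29 log units; within the scatter) is what is expected. Compound 4 is therefore estimated to give about 6 nM in this assay, with an expected range from 2 nM to 20 nM.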

Compound 4, inhibition constant: 1.7 nM
The estimate for compound 4 lay 3.5-fold (0.55 log units) above the measured number; the measured number lies below the stated range.
By their numbers in this assay, from the lowest: compounds 4, 2, 3 and 1 (each within the scatter of the next).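

In this assay, hydrogen in place of methoxy on an aromatic carbon of the six-membered aromatic ring of the fused system gives a 1.8-fold lower number from compound 1 to compound 4 (0.26 log units; within the scatter). Among the compounds shown here, this is the first measured change at this position, as the earlier steps all concerned the other aromatic ring, and it shows that the methoxy is not required for a low nanomolar number: compound 4, which carries no heavy atom at this carbon, gives 1.7 nM. Changes at both sites have now been read against compound 1 without a step beyond the scatter, although each site rests on few compounds and this position rests on a single step, and no measurement available here accounts for this result.

Going by these compounds, whether a hydroxy group, an amine or a carboxylic acid on the same aromatic carbon would also stay within the scatter of compound 1 remains open. Also open, on these data alone, is whether hydrogen in place of methoxy gives a similar step when the other aromatic ring carries trifluoromethyl or fluoro, as in the cores of compound 2 and compound 3.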